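Indole-benzothiazole urea series: removing one chloro from the benzyl group

This account rests on a few compounds, and the source may have more. Where it says the series, first, only, none or still open, it means among the compounds named here.

Measured compounds:
compound 1, `CN(C)Cc1ccc2nc(NC(=O)N/N=C/c3cn(Cc4ccc(Cl)cc4Cl)c4ccccc34)sc2c1`, 2000 nM
compound 2, `CCN(CC)Cc1ccc2nc(NC(=O)N/N=C/c3cn(Cc4ccc(Cl)cc4Cl)c4ccccc34)sc2c1`, 1900 nM

Both compounds were tested in a functional assay on A549 cells (Homo sapiens) for cytotoxicity, read by MTT assay, with a stated time of 72 h; on this read-out higher numbers stand for weaker inhibition and lower numbers for stronger inhibition. Compound 1 gives 2000 nM, and compound 2 gives 1900 nM. Going by the values given here, the one measured step, a 1.1-fold lower number from compound 1 to compound 2 (0.02 log units; within the scatter), shows that exchanging the amine on the saturated chain carbon leaves the read-out unchanged within the scatter, so compound 2 stands with compound 1 and neither can be called the more potent of the two.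

Compound 3, `CCN(CC)Cc1ccc2nc(NC(=O)N/N=C/c3cn(Cc4ccc(Cl)cc4)c4ccccc34)sc2c1`, has not yet been measured. It differs from compound 2 by hydrogen in place of chloro on an aromatic carbon; seen one bond further out, the 2,4-dichlorobenzyl group becomes a 4-chlorobenzyl group. Among the compounds with values here, no measured step bears on this change: the only step in hand, a 1.1-fold lower number from compound 1 to compound 2 (0.02 log units; within the scatter), concerns the amine end of the molecule and says nothing about the benzyl substituents. Within the data shown here, with no relevant step to anchor a direction, a modest loss is assumed as a plain working guess, and the expected step is a 1.6-fold higher number from compound 2 to compound 3 (0.20 log units; within the scatter). Compound 3 is therefore estimated at 3000 nM, with a range of 1000 nM to 9000 nM.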

Compound 3, half-maximal inhibitory concentration: 2940 nM
Compound 3: the middle estimate sits 1.0-fold (0.01 log units) above what was measured; the range from low to high includes it.
By their numbers in this assay, from the lowest: compounds 2, 1 and 3 (each within the scatter of the next).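

Going by these compounds alone, this is the first reading at the benzyl end of the series. In this assay, hydrogen in place of the chloro ortho to a large group gives a 1.5-fold higher number from compound 2 to compound 3 (0.19 log units; within the scatter), so the 2,4-dichlorobenzyl and 4-chlorobenzyl groups cannot be told apart on this read-out. With the other chloro kept in both compounds, the chloro at this position is not needed for the cytotoxicity seen here, just as the exchange of amine on the saturated chain carbon gave no separation between compound 1 and compound 2. No measured evidence is available to explain this result.

From the compounds shown here alone, whether the remaining chloro matters stays open, as a plain benzyl group with no chloro at all would be needed to test it, and a methoxy or trifluoromethyl group at the same aromatic carbon could also read differently. Going by these compounds, it is equally open whether a cyclic amine such as morpholine on the saturated chain carbon would separate from the dimethylamino and diethylamino compounds, or whether the 4-chlorobenzyl group behaves the same when paired with dimethylamino.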